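Removing a Methoxy Group from an Aryl Ester Cinnamate

A few compounds are considered here, and "the series" means these few. Any claim that something is new, unique, unknown or untested is made for them only; others in the source may bear on it.

Three compounds sharing one core were tested in a functional assay on EA.hy 926 cells (Homo sapiens) for cytotoxicity, read by MTT assay, with stated times of 24 h and 12 h, tested at 100 uM; a higher number here means a stronger effect of the compound at the concentration tested, a lower number a weaker effect. Compound 2, `COc1cc(/C=C/C(=O)O)cc(OC)c1OC(=O)c1nc(C)c(C)nc1C`, gives 163%. Compound 1, `COc1cc(/C=C/C(=O)O)ccc1OC(=O)c1nc(C)c(C)nc1C`, gives 55.4%; the change hydrogen in place of methoxy on an aromatic carbon made a number 107.6 percentage points lower from compound 2 to compound 1 (beyond the scatter). Compound 3, `CCOC(=O)/C=C/c1ccc(OC(=O)c2nc(C)c(C)nc2C)c(OC)c1`, gives 71.6%, and a number 16.2 percentage points higher from compound 1 to compound 3 (beyond the scatter). The difference between the cores of compound 3 and compound 2 is not broken down here.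

Compound 4, `CCOC(=O)/C=C/c1ccc(OC(=O)c2nc(C)c(C)nc2C)cc1`, has not yet been measured; it differs from compound 3 by hydrogen in place of methoxy on an aromatic carbon. Among the measured compounds shown here, this is the same kind of change as the one from compound 2 to compound 1, not the same: in that earlier pair the place was also meta to a methoxy group and meta to a 2-carboxyethenyl group, whereas in compound 3 it is meta to a 2-(ethoxycarbonyl)ethenyl group. Because a number 107.6 percentage points lower from compound 2 to compound 1 (beyond the scatter) was large, a drop from compound 3 to compound 4 is expected too. A percentage cannot fall below zero, so the step expected is smaller, namely a number 36.6 percentage points lower from compound 3 to compound 4 (beyond the scatter). Compound 4 is thus estimated at 35%, between 5% and 75%.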

Compound 4, a percentage reported as activity, at one concentration (the size of the read-out at that concentration, not a potency): 96.1%
Beside the measured number, compound 4's estimate is 61.1 percentage points below it; the measured number lies above the stated range.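

In this assay, replacing a methoxy group with hydrogen gives a number 24.5 percentage points higher from compound 3 to compound 4 (beyond the scatter), so the effect of this change does not carry over from one core to the other, not even in its direction: the same change on two cores in this assay, a number 107.6 percentage points lower (beyond the scatter) from compound 2 to compound 1 and a number 24.5 percentage points higher (beyond the scatter) from compound 3 to compound 4, 132.1 percentage points apart, beyond the scatter of two such steps The two pairs differ in more than one way: compound 1 is a carboxylic acid that keeps a methoxy group, whereas compound 4 is an ethyl ester with no methoxy group left. Two pairs cannot show which of these differences matters, or why the read-out moves as it does, only that a result from one core is a poor guide to the other in this series.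

As far as these compounds go, it remains open how the same change would behave on further cores, such as one with an amide in place of the ester. A longer chain in place of the ethyl group could follow the pattern of either pair, or neither.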